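Removing the Fluorine from the Sulfonyl Aryl Ring

The source may hold more compounds than are shown below. What is called first, only, known or untested is meant among the compounds shown, and "the series" means these compounds.

Of the compounds shown here, two built on one shared core have been tested in a functional assay on U-87MG ATCC cells for inhibition, with U-87 MG (Homo sapiens) as the target, read by sulforhodamine B assay, with a stated time of 72 h; on this read-out higher numbers stand for weaker inhibition of growth and lower numbers for stronger inhibition of growth. Compound 1, `O=S(=O)(Nc1cc(-c2cnc3[nH]cc(-c4ccncc4)c3c2)cnc1Cl)c1ccccc1F`, gives 7130 nM in this assay. Compound 2, `O=S(=O)(Nc1cc(-c2cnc3[nH]cc(-c4ccncc4)c3c2)cnc1Cl)c1ccc(F)cc1`, is reported in this assay only as a limit, > 10000 nM. Within the data shown here, the single measured step, an at least 1.4-fold higher number from compound 1 to compound 2 (0.14 log units; that floor lies within the scatter), therefore rests on that limit, (the limit of > 10000 nM in this assay, at which 1 of the 2 values shown sits), and its true size cannot be read; what the numbers do show is that compound 2 sits at the weak end of what this assay can report. Compound 3, `O=S(=O)(Nc1cc(-c2cnc3[nH]cc(-c4ccncc4)c3c2)cnc1Cl)c1ccccc1`, has not yet been measured. It differs from compound 2 in one place: hydrogen in place of fluoro on an aromatic carbon. Among the measured compounds shown here, no measured step covers this exact change, and the one step that exists ends on a limit, so it gives no firm direction. Since compound 2 already stands at the limit in this assay, compound 3 is expected to remain weak, with a step of about a number no higher from compound 2 to compound 3 (the limit leaves the size open) expected. Compound 3 is thus estimated to give roughly 10000 nM in this assay, somewhere between 3500 nM and 30000 nM, with a real chance that only a limit is reported again.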

Compound 3, concentration for 50% growth inhibition: 8950 nM
Beside the measured number, compound 3's estimate is 1.1-fold (0.05 log units) above it; measured number inside the range.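

Compound 3 shows how the sulfonyl aryl ring behaves with no fluoro on it at all, and in this assay the plain phenyl group cannot be told apart from the 2-fluorophenyl group: the step is a 1.3-fold higher number from compound 1 to compound 3 (0.10 log units; within the scatter). Replacing fluoro with hydrogen on the 4-fluorophenyl group gives an at least 1.1-fold lower number from compound 2 to compound 3 (0.04 log units; that floor lies within the scatter), so the floor of this step offers no evidence that the fluoro at this position matters, though it does not rule out a larger change. The true size of that step cannot be read, since one end of it is only a limit: the limit of > 10000 nM in this assay, at which 1 of the 3 values shown sits.

The compounds shown carry only fluoro or hydrogen on this ring, so it remains open whether a different group there, such as a methoxy group, an amine or a carboxylic acid, would shift growth inhibition beyond the usual scatter. As far as these compounds go, it also remains open whether changes elsewhere on the shared core would have more effect on this read-out than changes on the sulfonyl aryl ring.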